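Chloro for methoxy: compound 2 to compound 3

The compounds below may be only part of what the source reports. "The series", "measured", "known", "first", "only" and "open" are said of these compounds alone.

In a functional assay on MT4 cells (Homo sapiens) for cytotoxicity (a higher number here means that more compound is tolerated, a lower number that less compound is tolerated), compound 1 `Cc1c(O)nc(SCC(=O)c2ccc(Cl)cc2)nc1Cc1cccc2ccccc12` gives >= 198000 nM, which is a limit of the assay and not a number. Within the data shown here, compound 2 `CCc1c(O)nc(SCC(=O)c2ccc(OC)cc2)nc1Cc1cccc2ccccc12` gives 178000 nM, the only actual number so far. Compound 3 `CCc1c(O)nc(SCC(=O)c2ccc(Cl)cc2)nc1Cc1cccc2ccccc12` carries chloro in place of methoxy on an aromatic carbon, para to a large group (chloro in place of methoxy on an aromatic carbon). Among the measured compounds shown here, no measured step covers this change, so no shift beyond the scatter is expected in this assay, in either direction. The expectation rests on compound 2 at 178000 nM. The expected change is a 1.1-fold higher number from compound 2 to compound 3 (0.03 log units; within the scatter). For compound 3 the estimate is 190000 nM, with an expected range of 100000 nM to 300000 nM.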

Compound 3, half-maximal cytotoxic concentration: 56000 nM
Compound 3: middle estimate off by 3.4-fold (0.53 log units), on the high side, and the stated range ends above it.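

The change from 4-methoxyphenyl to 4-chlorophenyl gives a 3.2-fold lower number from compound 2 to compound 3 (0.50 log units; beyond the scatter) in this assay, so this aromatic carbon is not silent in this assay. Methyl in place of hydrogen on the saturated chain carbon gives an at least 3.5-fold lower number from compound 1 to compound 3 (0.54 log units; beyond the scatter), so the chain also matters here. Compound 1 stands at a limit and not a number, so that step has only a lower bound: the limit of >= 198000 nM in this assay, at which 1 of the 3 values shown sits.

From the compounds shown here alone, whether the shift belongs to chloro alone or would also follow an amine or a carboxylic acid on this aromatic carbon stays open. Going by these compounds, the effect of a longer chain also stays open.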